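One Added Methyl on the Amide Chain

The compounds below may be only part of what the source reports. "The series", "measured", "known", "first", "only" and "open" are said of these compounds alone.

Among the compounds with values here, compound 3 `CCNC(=O)c1ccc(S(N)(=O)=O)cc1` gives 0.03 in a physicochemical assay for lipophilicity (a lower number here means a more polar compound, a higher number a more lipophilic compound), the lowest of the three numbers so far. Compound 1 `CCCOC(=O)c1ccc(S(N)(=O)=O)cc1` stands at 1.75, and compound 2 `CCCCOC(=O)c1ccc(S(N)(=O)=O)cc1` stands at 2.34. Compound 4 `CCCNC(=O)c1ccc(S(N)(=O)=O)cc1` is reached by a small change: methyl in place of hydrogen on a saturated chain carbon, two bonds along the chain from an amide-type nitrogen. The same swap has been measured only once, on a propoxy chain rather than an ethylamino chain: a number 0.59 log units higher from compound 1 to compound 2 (beyond the scatter). A rise of similar size is therefore expected, a number 0.55 log units higher from compound 3 to compound 4 (beyond the scatter). For compound 4 the expected value is 0.58, with an estimated range of 0.25 to 0.9.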

Compound 4, partition coefficient: 0.51
The estimate for compound 4 lay 0.07 log units above the measured number; the range from low to high includes it.
By their numbers in this assay, from the lowest: compound 3; then compound 4; then compound 1; then compound 2.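

In this assay, going from ethylamino to propylamino gives a number 0.48 log units higher from compound 3 to compound 4 (beyond the scatter), so the added methyl also raises the number on an amide-type chain, not only on the propoxy chain, where the step was a number 0.59 log units higher from compound 1 to compound 2 (beyond the scatter). The extra methyl leaves the amide-type compound well short of the other two: propylamino in place of propoxy gives a number 1.24 log units lower from compound 1 to compound 4 (beyond the scatter), and propylamino in place of butoxy gives a number 1.83 log units lower from compound 2 to compound 4 (beyond the scatter). Nothing available gives a reason for these steps. From the compounds shown here alone, whether a longer chain such as butylamino would raise the number further remains open, as does the effect of an amine or a carboxylic acid on this chain.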